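The source may report more compounds than this note shows. Statements on the series, on what has been measured and on what is new or still open speak of the compounds shown alone.

Working notes on the urea series, in an ADME assay on the whole organism with Oryza sativa as the target, tested at 1 uM; on this read-out lower numbers stand for a stronger effect and higher numbers for a weaker effect at the one concentration tested.

Among the compounds with values here, compound 3, `CC(=O)c1cccc(NC(=O)N[C@@H](C)c2ccccc2)c1`, gives 95% and stands highest of the three numbers so far. Compound 2, `CC(=O)c1cccc(NC(=O)N[C@H](C)c2ccccc2)c1`, gives 88%; compound 1, `CC(C)c1cccc(NC(=O)N[C@@H](C)c2ccccc2)c1`, gives 84%. Of the two steps into compound 3, a number 11 percentage points higher from compound 1 to compound 3 (beyond the scatter), while a number 7 percentage points higher from compound 2 to compound 3 (within the scatter), a step that rests only on (the fact that compounds 2 and 3 differ only in the configuration as drawn).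

Compound 4 is `C[C@H](NC(=O)Nc1cccc(Br)c1)c1ccccc1`, not yet measured. Against compound 3 the change is bromo in place of acetyl on an aromatic carbon. The step from compound 1 to compound 3 is the one that bears on it, since it too replaces the group on that aromatic carbon, and it moved the read-out by a modest margin. The step from compound 2 to compound 3 touches no substituent and says little here. A step of comparable size is therefore plausible, and a direction back toward the number of compound 1 seems the more likely of the two, though it may also stay within the scatter of compound 3.

For compound 4 the expectation in this assay is 87%, with a range of 73% to 98%, which is an expected step of a number 8 percentage points lower from compound 3 to compound 4 (within the scatter).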

Compound 4, a percentage reported as activity, at one concentration (the size of the read-out at that concentration, not a potency): 100%
The estimate for compound 4 lay 13 percentage points below the measured number, outside the stated range (above it).
By their numbers in this assay, from the lowest: compounds 1, 2, 3 and 4 (each within the scatter of the next, the first and the last beyond it).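

In this assay, replacing acetyl with bromo on this aromatic carbon gives a number 5 percentage points higher from compound 3 to compound 4 (within the scatter) and so does not separate the two groups, even though the hydrogen-bond acceptor and the double bond counted on acetyl are absent from bromo. Isopropyl does separate from bromo at the same carbon, with a number 16 percentage points higher from compound 1 to compound 4 (beyond the scatter) in the same direction as the earlier step from isopropyl to acetyl, so among the three groups only isopropyl stands apart, and only by a modest margin. The only thing known here beyond the numbers concerns configuration and does not touch this exchange, so no cause can be given for either step.

Still open, on these data alone, is whether a group such as an amine, a carboxylic acid, a methoxy group or a longer alkyl chain on this aromatic carbon would bring the number down past that of compound 1 or leave it with compound 3 and compound 4. Also open, as far as these compounds go, is whether the mirror-image configuration of compound 4 would sit as close to it as compound 2 does to compound 3.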